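The source may report more compounds than this note shows. Statements on the series, on what has been measured and on what is new or still open speak of the compounds shown alone.

Working notes on the series around compound 2 `COc1ccc(C2C(C#N)=C(N)OC(c3c[nH]c4ccccc34)=C2C#N)cc1` and its neighbours.

The common core is varied only at the aryl group attached to the saturated ring carbon. Compound 1 `N#CC1=C(N)OC(c2c[nH]c3ccccc23)=C(C#N)C1c1ccccc1F` carries a fluorine on that ring; in a functional assay, tested at 400 ug/mL (on this read-out lower numbers stand for a weaker effect and higher numbers for a stronger effect at the one concentration tested), compound 1 is reported as "not active" (no number reported), with no number given for it. Among the measured compounds shown here, compound 2 carries a methoxy group on the same ring; in this assay compound 2 gives 28.7%, the only number in the set so far, the one further entry being the one without a figure.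

Compound 3 `N#CC1=C(N)OC(c2c[nH]c3ccccc23)=C(C#N)C1c1ccccc1` is the unsubstituted analogue: hydrogen in place of methoxy on an aromatic carbon, or, cut one bond further out, 4-methoxyphenyl to phenyl. For the measured compounds named here, no step between two measured compounds is available to set the size of this change. From compound 2 at 28.7%, the step to the unsubstituted ring is expected to be small to moderate and downward, as a number 7.7 percentage points lower from compound 2 to compound 3 (within the scatter), though a result within the scatter would not be surprising either. Compound 3 is therefore expected to give about 21%, with a range from 5% to 38%, and some chance that it too is reported as not active without a figure.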

Compound 3, a percentage reported as activity, at one concentration (the size of the read-out at that concentration, not a potency): 26.7%
Compound 3: the middle estimate sits 5.7 percentage points below what was measured; the measured number falls inside the stated range.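

The step of a number 2 percentage points lower from compound 2 to compound 3 (within the scatter) gives the first size for this change: with hydrogen in place of methoxy on an aromatic carbon of the ring, para to a large group, the two compounds cannot be told apart in this assay at the one concentration tested, so a reported figure on this read-out does not depend on the methoxy group. Compound 3 also gives the unsubstituted ring as a reference for the series, yet compound 1, with its fluorine on that ring, is reported as "not active" (no number reported) and its steps to the other two cannot be read as sizes. Nothing measured on these compounds offers an explanation for either observation.

Going by these compounds, it remains open whether an amine, a carboxylic acid or a longer chain such as butoxy in place of methoxy would shift the read-out beyond the scatter, or whether this place simply tolerates substitution. Also open, on these data alone, is whether the missing figure for compound 1 belongs to fluorine as such or to where that atom sits on the ring, which a chlorine or a second fluorine on the ring could begin to separate.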